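This account rests on a few compounds, and the source may have more. Where it says the series, first, only, none or still open, it means among the compounds named here.

Compound 2, `N#Cc1c(Nc2ccccn2)nc(SCc2nc3ccccc3[nH]2)nc1-c1ccccc1`, gives 2.55 nM in a functional assay on U-937 cells (Homo sapiens) for cytotoxicity, read by MTT assay, with a stated time of 3 days (on this read-out higher numbers stand for weaker inhibition and lower numbers for stronger inhibition), the lower of the two numbers shown; its only neighbour is compound 1, `N#Cc1c(Cl)nc(SCc2nc3ccccc3[nH]2)nc1-c1ccccc1`, which in this assay gives 4.46 nM, and the two lie within the scatter of each other. Compound 3, `CN1CCN(c2nc(SCc3nc4ccccc4[nH]3)nc(-c3ccccc3)c2C#N)CC1`, has not yet been measured. Its change from compound 2 is 4-methylpiperazin-1-yl in place of (pyridin-2-yl)amino on an aromatic carbon. Going by the values given here, the one measured step at this same position, a 1.7-fold lower number from compound 1 to compound 2 (0.24 log units; within the scatter), shows that the position accepts a different group without a change beyond the scatter, so the step to compound 3 is expected to be small as well, with no direction that can be told from the data. The estimated step is therefore a 1.2-fold higher number from compound 2 to compound 3 (0.07 log units; within the scatter). Compound 3 is expected to give about 3 nM in this assay, within a range of 1 nM to 10 nM.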

Compound 3, half-maximal inhibitory concentration: 6.75 nM
Compound 3: middle estimate off by 2.3-fold (0.35 log units), on the low side; the range from low to high includes it.
By their numbers in this assay, from the lowest: compounds 2, 1 and 3 (each within the scatter of the next, the first and the last beyond it).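

In this assay, going by these compounds alone, the exchange of (pyridin-2-yl)amino for 4-methylpiperazin-1-yl, a 2.6-fold higher number from compound 2 to compound 3 (0.42 log units; beyond the scatter), gives the first step beyond the scatter at this position, so the position does not accept every change without effect, although the step is modest. The same group in place of chloro, a 1.5-fold higher number from compound 1 to compound 3 (0.18 log units; within the scatter), stays within the scatter, so the size of the step depends on which group leaves. The two exchanged groups have the same heavy-atom count, but they differ in ring type and in the hydrogen-bond donor, and nothing available explains the step.

The compounds shown leave open whether the loss of the donor or the change of ring goes with the step. A phenylamino group or a piperazin-1-yl group without the methyl would be needed to separate these two differences.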